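Cyanoguanidine chain variants on the pyridazinone series

The compounds below may be only part of what the source reports. "The series", "measured", "known", "first", "only" and "open" are said of these compounds alone.

Measured so far:
Compound 1, `C/N=C(/NC#N)NCCCCCn1nc(-c2ccccc2)ccc1=O`, 47.6%
Compound 2, `C/N=C(/NC#N)N(C)CCCCn1nc(-c2ccccc2)ccc1=O`, 27%

Compound 2 stands lowest of the two numbers in a functional assay on the whole organism with Rattus norvegicus as the target, at a dose of 100 mg/kg; a lower number here means less inhibition, a higher number more inhibition at the dose given (going by the name of the read-out); the nearest, compound 1, lies higher by a step beyond the scatter, a number 20.6 percentage points lower from compound 1 to compound 2 (beyond the scatter).

Compound 3, `C/N=C(\NC#N)NCCCCn1nc(-c2ccccc2)ccc1=O`, differs from compound 2 in a group of 7 heavy atoms (3 carbon, 4 nitrogen; no ring) in place of a group of 8 heavy atoms (4 carbon, 4 nitrogen; no ring), on a saturated chain carbon, four bonds along the chain from an aromatic nitrogen. It keeps the chain length of compound 2 but carries the unsubstituted terminal nitrogen of compound 1. Going by the values given here, the only measured step that bears on this, a number 20.6 percentage points lower from compound 1 to compound 2 (beyond the scatter), bundles a chain change with the nitrogen change, so it cannot be split cleanly; its size suggests the nitrogen substitution alone could account for part of it. The expected direction is upward, of modest size, possibly within scatter.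

Compound 3 is therefore expected to give 40%, within 22% to 58%, a step of a number 13 percentage points higher from compound 2 to compound 3 (beyond the scatter) in this assay.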

Compound 3, a percentage reported as inhibition, in the whole organism at one dose (the size of the read-out at that dose, not a potency): 79%
Compound 3: middle estimate off by 39 percentage points, on the low side; measured number above the stated range.
By their numbers in this assay, from the lowest: compound 2; then compound 1; then compound 3.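

In this assay, the group of 7 heavy atoms on a saturated chain carbon, four bonds along the chain from an aromatic nitrogen, gives a large rise over the group of 8 heavy atoms (a number 52 percentage points higher from compound 2 to compound 3 (beyond the scatter)). A rise also appears against the chain-variant comparator (a number 31.4 percentage points higher from compound 1 to compound 3 (beyond the scatter)), so compound 3 stands highest of the three, and the earlier drop did not show how much this position can gain from the entering group with 2 hydrogen-bond donors. No measurement here explains the rise.

Still open, from the compounds shown here alone, is how an ethyl group on the terminal nitrogen, or a longer chain carrying the same unsubstituted end, would compare with compound 3. Also open, going by these compounds, is whether a thiourea in place of the cyanoguanidine would hold this level.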